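From 2-ethylphenyl to pentyl on an aromatic nitrogen

The source may hold more compounds than are shown below. What is called first, only, known or untested is meant among the compounds shown, and "the series" means these compounds.

In a functional assay on HepG2 cells (Homo sapiens) for antiproliferative activity, read by MTT assay (a higher number here means a weaker inhibitor, a lower number a stronger inhibitor), compound 1 `CC1(C)CCc2cc(C(=O)/C=C/c3ccc(OCc4cn(-c5ccc(Cl)cc5)nn4)cc3)c(O)cc2O1` is reported as "not active" (no number reported) without a number, and compound 2 `CC(=O)c1ccc(-n2cc(COc3ccc(/C=C/C(=O)c4cc5c(cc4O)OC(C)(C)CC5)cc3)nn2)cc1` as "not active" (no number reported) without a number. Among the measured compounds shown here, by contrast, compound 3 `CCc1ccccc1-n1cc(COc2ccc(/C=C/C(=O)c3cc4c(cc3O)OC(C)(C)CC4)cc2)nn1` gives 115000 nM and so holds the only number. The next member, compound 4 `CCCCCn1cc(COc2ccc(/C=C/C(=O)c3cc4c(cc3O)OC(C)(C)CC4)cc2)nn1`, carries pentyl in place of 2-ethylphenyl on an aromatic nitrogen, and pentyl in place of 2-ethylphenyl on an aromatic nitrogen sums up that change. For the measured compounds named here, no measured step shows the size of such a swap, so no shift beyond the usual scatter is expected, in either direction. The estimated move is a 1.3-fold lower number from compound 3 to compound 4 (0.11 log units; within the scatter) and it stays within that scatter. Thus compound 4 is expected at 90000 nM within an estimated range of 30000 nM to 250000 nM in this measurement.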

Compound 4, half-maximal inhibitory concentration: 95800 nM
Compound 4: the middle estimate sits 1.1-fold (0.03 log units) below what was measured, and the stated range covers the measured number.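

In this assay, among the compounds shown here, pentyl in place of 2-ethylphenyl gives a 1.2-fold lower number from compound 3 to compound 4 (0.08 log units; within the scatter), the first measured step at this aromatic nitrogen. Exchanging the six-membered aromatic ring for an open chain with fewer heavy atoms therefore leaves the reading within the scatter. Nothing shown here offers an explanation for this result.

Steps to compound 1 and compound 2 cannot be read, since neither has a number. As far as these compounds go, whether a terminal amine or carboxylic acid on the pentyl chain would shift the reading remains open.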